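The source may report more compounds than this note shows. Statements on the series, on what has been measured and on what is new or still open speak of the compounds shown alone.

Compound 2 `Cc1cc(Nc2cc(Cl)c(Oc3ccccc3)c(Cl)c2)nc(N)n1` is known in an assay on cells for inhibition of S-adenosylmethionine decarboxylase proenzyme (Homo sapiens), read by mass spectrometry, at pH 7.2 (a higher number here means a weaker inhibitor, a lower number a stronger inhibitor), only as a limit, giving > 180000 nM. Compound 1 `Cc1cc(Nc2cccc(F)c2)nc(N)n1` likewise reaches only a limit in this assay, at > 180000 nM. For the measured compounds named here, both measured values therefore sit at the limit of > 180000 nM in this assay, at which 2 of the 2 values shown sit, and no step between measured compounds can be read from them. Compound 3 `Cc1cc(Nc2cc(Cl)c(N3CCCCC3)c(Cl)c2)nc(N)n1` differs from compound 2 by piperidin-1-yl in place of phenoxy on an aromatic carbon. With nothing measured to build on, no step beyond the scatter is expected, and the estimated change from compound 2 to compound 3 is a step that the limit leaves unreadable from compound 2 to compound 3. Compound 3 is accordingly expected to give about 200000 nM in this assay, within a range from 40000 nM to 1000000 nM.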

Compound 3, half-maximal inhibitory concentration: > 180000 nM
Compound 3 ended at the assay's limit (the forecaster's own chance of this, stated with the estimate: 80%); the middle value is on the limit's open side.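

Compound 3, like compound 2, gives only a limit in this assay, so no step can be read between compound 2 and compound 3: the limit of > 180000 nM in this assay, at which 3 of the 3 values shown sit.

The compounds shown leave open which change to the shared core, if any, would bring a measurable value in this assay.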